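Cytotoxicity in MT4 cells across three thiophene carboxylic acids and a fourth

A few compounds are considered here, and "the series" means these few. Any claim that something is new, unique, unknown or untested is made for them only; others in the source may bear on it.

Compound 1, `CC(C)N(c1cc(C#CC(C)(C)C)sc1C(=O)O)C(=O)[C@H]1CC[C@H](Cl)CC1`, in an ADME assay on MT4 cells (Homo sapiens) for cytotoxicity, with a stated time of 5 days (on this read-out higher numbers stand for lower toxicity in this test and lower numbers for higher toxicity in this test), gives > 20000 nM, a limit of the assay.
Compound 2, `CC(C)N(C(=O)[C@H]1CC[C@@H]2C[C@@H]2CC1)c1cc(C#CC(C)(C)C)sc1C(=O)O`, in this assay gives > 20000 nM, again a limit.
Compound 3, `CC(C)(C)C#Cc1cc(N(C(=O)[C@H]2CC[C@H](C)CC2)[C@H]2CC[C@H](O)CC2)c(C(=O)O)s1`, in this assay gives > 20000 nM, also a limit.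

Compound 2 therefore stands at a limit, and so do the two other values shown; none of the three is a number. Among the compounds with values here, the only single-point step among them, a step that the two limits leave unreadable from compound 1 to compound 2, is unreadable for that reason. Within the data shown here, the one piece of evidence is the limit of > 20000 nM in this assay, at which 3 of the 3 values shown sit, which says that every measurement so far sits at the same limit.

Compound 4, `CC(C)N(C(=O)C1CCCCC1)c1cc(C#CC(C)(C)C)sc1C(=O)O`, differs from compound 2 by a group of 6 heavy atoms (6 carbon; one six-membered non-aromatic ring of carbon only) in place of a group of 8 heavy atoms (8 carbon; one three-membered non-aromatic ring of carbon only, one seven-membered non-aromatic ring of carbon only), on a carbonyl carbon. Since all measured compounds, across three different groups on that carbonyl carbon, sit at the limit, no direction of change can be read, and none beyond the scatter is expected for compound 4. The step that the limit leaves unreadable from compound 2 to compound 4 is thus estimated to stay close to nothing. Compound 4 is expected to give about 30000 nM, within 15000 nM to 80000 nM, most likely reported again as a limit.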

Compound 4, half-maximal cytotoxic concentration: > 20000 nM
Compound 4: no number, only a limit; the forecaster's own chance of this, stated with the estimate: 85%; the middle value is on the limit's open side.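

Compound 4, like compound 1 and compound 2, gives only a limit in this assay, and neither the step from compound 2 to compound 4 nor that from compound 1 to compound 4 can be read. The compounds shown leave open whether any group on the carbonyl carbon changes this read-out at all, for all that stands is this: the limit of > 20000 nM in this assay, at which 4 of the 4 values shown sit.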